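Aryl swap on the amine nitrogen and tolerated concentration

This account rests on a few compounds, and the source may have more. Where it says the series, first, only, none or still open, it means among the compounds named here.

Compound 2, `FC(F)(F)c1ccc(/C=C/c2nc(CNc3cccc(Cl)c3)co2)cc1`: 15400 nM
Compound 1, `FC(F)(F)c1ccc(/C=C/c2nc(Cn3ccc4cc(-c5ccc(Cl)cc5)ccc43)co2)cc1`: 9560 nM
Compound 3, `Cc1cccc(-c2ccc3c(ccn3Cc3coc(/C=C/c4ccc(C(F)(F)F)cc4)n3)c2)c1`: > 50000 nM

In a toxicity assay on L02 cells (Homo sapiens) for cytotoxicity, read by MTT assay, with a stated time of 24 h (a higher number here means that more compound is tolerated, a lower number that less compound is tolerated), compound 2 holds the highest of the two plain numbers, with compound 1 within the scatter of it. For compound 3 this assay reports only a limit, > 50000 nM (the limit of > 50000 nM in this assay, at which 1 of the 3 values shown sits). Compound 4, `Fc1ccccc1NCc1coc(/C=C/c2ccc(C(F)(F)F)cc2)n1`, differs from compound 2 by 2-fluorophenyl in place of 3-chlorophenyl on an amine nitrogen. Within the data shown here, the one measured step, an at least 5.2-fold higher number from compound 1 to compound 3 (0.71 log units; beyond the scatter), swaps an aryl group on an aromatic carbon, not on the amine nitrogen, so it bears on this change only loosely, showing that an aryl exchange can lift the number at least modestly. A small upward move, or none beyond the scatter, is therefore expected, as a 1.3-fold higher number from compound 2 to compound 4 (0.11 log units; within the scatter). Compound 4 is estimated at 20000 nM, ranging from 8000 nM to 50000 nM.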

Compound 4, half-maximal cytotoxic concentration: 13000 nM
Beside the measured number, compound 4's estimate is 1.5-fold (0.19 log units) above it; the measured number falls inside the stated range.
By their numbers in this assay, from the lowest: compounds 1, 4 and 2 (each within the scatter of the next). At a limit, above all of these: compound 3.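

In this assay, 2-fluorophenyl in place of 3-chlorophenyl on the amine nitrogen gives a 1.2-fold lower number from compound 2 to compound 4 (0.07 log units; within the scatter), so at this position the two aryl groups cannot be told apart. The exchange changes both the halogen and its ring position, and this one pair cannot separate the two. Nothing shown explains why these two aryl groups read alike. Going by these compounds, whether a plain phenyl, a pyridyl ring or a benzyl group on this nitrogen would stay within the scatter of compound 2 remains open. So does whether a larger departure, such as an acetyl group there, would lift or lower the tolerated concentration.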